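This account rests on a few compounds, and the source may have more. Where it says the series, first, only, none or still open, it means among the compounds named here.

Three compounds sharing one core are compared here in a functional assay on HeLa cells (Homo sapiens) for cytotoxicity, read by MTT assay, with a stated time of 24 h; a higher number here means a weaker inhibitor, a lower number a stronger inhibitor. For the measured compounds named here, compound 1 `COc1cc(/C=C2\CN(C)C/C(=C\c3ccc(Br)cc3)C2=O)cc(OC)c1OC` gives 11900 nM, the only exact number so far. Compound 2 `CN1C/C(=C\c2ccc(Cl)cc2)C(=O)/C(=C/c2cccc([N+](=O)[O-])c2)C1` gives > 20000 nM, which is a limit of the assay and not a number. Its place on the scale is therefore (the limit of > 20000 nM in this assay, at which 1 of the 2 values shown sits). Going by these compounds, its true value is unknown, so any comparison with it stays loose.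

Compound 3 `CN1C/C(=C\c2cccc([N+](=O)[O-])c2)C(=O)/C(=C/c2ccc(Cl)cc2Cl)C1` differs from compound 2 by a single change: chloro in place of hydrogen on an aromatic carbon. In words, this is chloro in place of hydrogen on an aromatic carbon, which turns the 4-chlorophenyl group into a 2,4-dichlorophenyl group. Going by the values given here, no measured pair here shows what such a swap does, so the expectation leans on compound 1 at 11900 nM, the one exact reading for this core. What is expected is an at least 1.2-fold lower number from compound 2 to compound 3 (0.09 log units; that floor lies within the scatter), a modest move toward stronger inhibition that may not clear the usual scatter. Compound 3 is estimated at 16000 nM, with an expected range of 7000 nM to 30000 nM.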

Compound 3, half-maximal inhibitory concentration: 8900 nM
Compound 3: middle estimate off by 1.8-fold (0.25 log units), on the high side; the measured number falls inside the stated range.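

In this assay, the added chloro, which turns the 4-chlorophenyl group into a 2,4-dichlorophenyl group, gives an at least 2.2-fold lower number from compound 2 to compound 3 (0.35 log units; beyond the scatter). For the compounds shown here, this is the first direct evidence of what this swap does on the shared core: a chloro placed on this aromatic carbon, ortho to a large group, goes with a lower number and so with stronger inhibition, rather than with a loss of activity. The exact size of the step remains unknown because one end of it is a limit of the assay and not a number: the limit of > 20000 nM in this assay, at which 1 of the 3 values shown sits.

The compounds shown leave open whether a fluoro, methyl or methoxy group on this same carbon would lower the number as well, or whether the effect is particular to chloro. They also leave open how large the same change would be on a compound whose starting value is an exact number, which would turn this floor into a measured step.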